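The compounds below may be only part of what the source reports. "The series", "measured", "known", "first", "only" and "open" are said of these compounds alone.

Compound 1 `CS(=O)(=O)N1CCC2(CC1)OOC1(CCCCC1)OO2` and compound 2 `CS(=O)(=O)N1CCC2(CC1)OOC1(CCCCCC1)OO2` each carry a methylsulfonyl group on a shared core; how the two cores differ is not broken down here. Compound 3 `CCS(=O)(=O)N1CCC2(CC1)OOC1(CCCCC1)OO2` is compound 1 with one change, (methyl in place of hydrogen on a saturated chain carbon bound to a sulfonyl sulfur). Compound 4 `CCS(=O)(=O)N1CCC2(CC1)OOC1(CCCCCC1)OO2`, not yet measured, is compound 2 with the same change made at the same place, (methyl in place of hydrogen on a saturated chain carbon bound to a sulfonyl sulfur).

In a functional assay on Huh-7 cells (Homo sapiens) for cytotoxicity, read by MTT assay, with a stated time of 72 h (on this read-out lower numbers stand for higher toxicity in this test and higher numbers for lower toxicity in this test), compound 1 gives only a limit of the test, > 100 ug/mL. In this assay compound 3 likewise gives a limit, > 100 ug/mL. The step that the two limits leave unreadable from compound 1 to compound 3 therefore cannot be sized. In this assay compound 2 also gives a limit, > 100 ug/mL. All three measured values sit at the limit of > 100 ug/mL in this assay, at which 3 of the 3 values shown sit, so none of them is set apart from the others, and nothing here shows one compound to be more or less toxic than another.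

Among the measured compounds shown here, for the same kind of change on the core of compound 2, a step of roughly a step that the limit leaves unreadable from compound 2 to compound 4 is expected in this assay because the step that the two limits leave unreadable from compound 1 to compound 3 stayed hidden under the limit, and because the limit of > 100 ug/mL in this assay, at which 3 of the 3 values shown sit, is where every value so far has landed. Compound 4 is thus estimated to give about 150 ug/mL in this assay, most probably again as a limit, with an expected range from 70 ug/mL to 400 ug/mL.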

Compound 4, half-maximal cytotoxic concentration: > 100 ug/mL
Compound 4 was reported as a limit; the forecaster's own chance of this, stated with the estimate: 85%; the middle value lies beyond the limit too.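

In this assay compound 4 gives > 100 ug/mL, which is a limit of the test. Compound 2 also gives only a limit, so no step can be read between compound 2 and compound 4. Every value shown stands at the same place: the limit of > 100 ug/mL in this assay, at which 4 of the 4 values shown sit. The compounds shown leave open how toxic any of them actually is, and whether methyl to ethyl changes that toxicity on either core.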